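The compounds below may be only part of what the source reports. "The series", "measured", "known", "first", "only" and "open" are said of these compounds alone.

Three compounds have been measured in an assay for displacement of a labelled ligand from melanin-concentrating hormone receptor 1 (Homo sapiens), read by fluorescence; on this read-out lower numbers stand for stronger inhibition and higher numbers for weaker inhibition:

Compound 1 `CC(=O)Nc1cccc(C2CCN(CCCn3c(-c4ccccc4)nc4ccccc43)CC2)c1`: 2 nM
Compound 2 `CC(=O)Nc1cccc(C2CCN(CCCn3c(-c4cccc(Cl)c4)nc4ccccc43)CC2)c1`: 5 nM
Compound 3 `CC(=O)Nc1cccc(C2CCN(CCCn3c(-c4ccc(F)c(F)c4)nc4ccccc43)CC2)c1`: 4 nM

Compound 2 gives the highest of these three numbers; its gap to compound 3 is within the scatter, while the step of a 2.5-fold higher number from compound 1 to compound 2 (0.40 log units; beyond the scatter) lies beyond it. Compound 4 `CC(=O)Nc1cccc(C2CCN(CCCn3c(-c4ccc(F)cc4Cl)nc4ccccc43)CC2)c1` differs from compound 2 in one place: 2-chloro-4-fluorophenyl in place of 3-chlorophenyl on an aromatic carbon. Within the data shown here, two measured steps bear on this change. The step of a 2.5-fold higher number from compound 1 to compound 2 (0.40 log units; beyond the scatter) was modest, and the step of a 1.3-fold lower number from compound 2 to compound 3 (0.10 log units; within the scatter), in which one halogenated ring replaced another, stayed within the scatter. Compound 4 again carries halogens on the same ring, and the expected step of a 1.2-fold higher number from compound 2 to compound 4 (0.08 log units; within the scatter) is therefore small, with no direction beyond the scatter. Compound 4 is estimated at 6 nM, with a range from 2.5 nM to 15 nM.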

Compound 4, half-maximal inhibitory concentration: 4 nM
Estimate against measurement, compound 4: 1.5-fold (0.18 log units) above; the measured number falls inside the stated range.
By their numbers in this assay, from the lowest: compounds 1, 3, 4 and 2 (each within the scatter of the next, the first and the last beyond it).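

Placing 2-chloro-4-fluorophenyl on this aromatic carbon gives a 1.3-fold lower number from compound 2 to compound 4 (0.10 log units; within the scatter) and no change at the digits printed from compound 3 to compound 4 (within the scatter), so this third halogen pattern on the ring cannot be told apart from the other two. Unlike compound 2, compound 4 also stays within the scatter of the unsubstituted phenyl, with a 2.0-fold higher number from compound 1 to compound 4 (0.30 log units; within the scatter). No measurement here explains why these rings read so alike.

Still open, on these data alone, is whether a methoxy group or an amine on this phenyl ring, or a pyridine ring in its place, would read the same.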